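A few compounds are considered here, and "the series" means these few. Any claim that something is new, unique, unknown or untested is made for them only; others in the source may bear on it.

Compound 2, `CCCN(CC#Cc1cc2ncnc(Nc3ccc(OCc4cccc(F)c4)c(Cl)c3)c2s1)CCC`, is tested in an ADME assay on NIH3T3 cells (Mus musculus) for cytotoxicity; a lower number here means that less compound is tolerated, a higher number that more compound is tolerated. In that setting compound 2 gives > 50 uM, which is a limit of the assay and not a number. Its nearest measured relative is compound 1, `CCOC(=O)CN(C)CC#Cc1cc2ncnc(Nc3ccc(OCc4cccc(F)c4)c(Cl)c3)c2s1`, which differs in one place and in this assay gives 52 uM. The step between them, a step that the limit leaves unreadable from compound 1 to compound 2, cannot be sized, since the limit of > 50 uM in this assay, at which 1 of the 2 values shown sits, marks where compound 2 sits rather than a value.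

Compound 3, `Fc1cccc(COc2ccc(Nc3ncnc4cc(C#CC5CCCC5)sc34)cc2Cl)c1`, has not yet been measured in this assay. It departs from compound 2 by cyclopentyl in place of (dipropylamino)methyl on a triple-bonded carbon. Among the measured compounds shown here, no measured step exchanges a (dipropylamino)methyl group for a cyclopentyl group on a triple-bonded carbon, and the single known step, a step that the limit leaves unreadable from compound 1 to compound 2, offers no readable size to lean on. The two measured values sit close to one another, so there is no indication of a large move in either direction. The step expected here, a number no higher from compound 2 to compound 3 (the limit leaves the size open), is therefore taken to be none beyond the scatter. Compound 3 is accordingly estimated at 50 uM, with a range from 20 uM to 120 uM.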

Compound 3, half-maximal toxic concentration: > 100 uM
Compound 3 was reported as a limit; the forecaster's own chance of this, stated with the estimate: 55%; middle value at least 2.0-fold (0.30 log units) from the limit.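

Among the compounds shown here, compound 3 stands at > 100 uM in this assay, which is a limit of the assay and not a number, and it carries on the triple-bonded carbon a cyclopentyl group with no nitrogen, where the earlier compounds showed this position only with amine-bearing chains. The one readable step is an at least 1.9-fold higher number from compound 1 to compound 3 (0.28 log units; that floor lies within the scatter), so replacing the whole amine-bearing chain with a ring of carbon only gave no lower number here, though the change is not shown to lie beyond the scatter. The step that links compound 2 and compound 3 cannot be read, and neither compound can be ranked against the other: the limit of > 100 uM in this assay, at which 1 of the 3 values shown sits.

On these data alone, what remains open is how much compound is actually tolerated for compound 2 and compound 3, and so whether the dipropylamino and cyclopentyl groups differ at all in this assay. As far as these compounds go, it is also open whether a carboxylic acid, a primary amine or a phenyl ring on the same triple-bonded carbon would give a number that can be read rather than another limit.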